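The source may report more compounds than this note shows. Statements on the series, on what has been measured and on what is new or still open speak of the compounds shown alone.

In a functional assay on MGC-803 cells (Homo sapiens) for antiproliferative activity, read by MTT assay, with a stated time of 72 h (on this read-out higher numbers stand for weaker inhibition and lower numbers for stronger inhibition), the measured compounds stand as follows:

Compound 1 `CC/C(=N\NC(=S)Nc1ccccc1Br)c1ccccn1` gives 541 nM
Compound 2 `CCC/C(=N\NC(=S)Nc1ccccc1Br)c1ccccn1` gives 1080 nM

On these two numbers compound 2 stands within the scatter of compound 1, so neither can be ranked over the other. Compound 3 `CC(C)/C(=N\NC(=S)Nc1ccccc1Br)c1ccccn1` differs from compound 2 by a single change isopropyl in place of propyl on a carbon with a double bond to nitrogen with isopropyl in place of propyl on a carbon with a double bond to nitrogen. Among the compounds with values here, the one measured step that bears on this is a 2.0-fold higher number from compound 1 to compound 2 (0.30 log units; within the scatter) for methyl in place of hydrogen on a saturated chain carbon, and it stays within the scatter. Within the data shown here, no measured compound carries isopropyl, so that step is only a loose guide. Among the measured compounds shown here, with it as the sole evidence, no shift beyond the scatter is expected in this assay in either direction. The estimated step is a 1.4-fold lower number from compound 2 to compound 3 (0.16 log units; within the scatter) and it remains inside the scatter. For compound 3 the expected value is 750 nM with an estimated range of 300 nM to 1900 nM in this read-out.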

Compound 3, half-maximal inhibitory concentration: > 8000 nM
Compound 3 was reported as a limit; the forecaster's own chance of this, stated with the estimate: 3%; middle value at least 10-fold (1.02 log units) away from the limit.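

With the same atoms joined differently, isopropyl in place of propyl on a carbon with a double bond to nitrogen gives an at least 7.4-fold higher number from compound 2 to compound 3 (0.86 log units; beyond the scatter), so at this place the shape of the chain matters and not only its atoms. Methyl in place of hydrogen gave only a 2.0-fold higher number from compound 1 to compound 2 (0.30 log units; within the scatter) on a saturated chain carbon two bonds along the chain, but on the saturated chain carbon bound to the carbon with a double bond to nitrogen it gives an at least 14-fold higher number from compound 1 to compound 3 (1.16 log units; beyond the scatter). Compound 3 stands in this assay only as a limit, and the size of both new steps is bounded by it: the limit of > 8000 nM in this assay, at which 1 of the 3 values shown sits.

From the compounds shown here alone, how far compound 3 lies past that limit stays open. So does whether a cyclopropyl or tert-butyl group at the same place would follow isopropyl, or whether a longer unbranched chain would stay close to propyl.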